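Thiazole amide replacing the nitrophenyl amide in compound 3

This account rests on a few compounds, and the source may have more. Where it says the series, first, only, none or still open, it means among the compounds named here.

The two measured compounds share one core and differ only in the group on the outer amide. Compound 1 `O=C(COc1ccc2c(=O)ccoc2c1)Nc1cccc(NC(=O)c2ccc(F)cc2)c1` carries fluoro on an aromatic carbon, and in an assay on isolated protein for inhibition of Rho-associated protein kinase 2 (Homo sapiens), read by scintillation counting, radiometric assay and 33P incorporation, with a stated time of 40 min, in the presence of a further agent that is not named here (on this read-out lower numbers stand for stronger inhibition and higher numbers for weaker inhibition), compound 1 gives 54 nM. Compound 2 `O=C(COc1ccc2c(=O)ccoc2c1)Nc1cccc(NC(=O)c2ccc([N+](=O)[O-])cc2)c1` carries nitro in place of fluoro on an aromatic carbon, and in this assay compound 2 gives 15 nM. The step between them, a 3.6-fold lower number from compound 1 to compound 2 (0.56 log units; beyond the scatter), is the only one measured so far. For the measured compounds named here, compound 2 therefore stands at the lowest of the two numbers, with compound 1 as its only neighbour at a higher value.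

Compound 3 `O=C(COc1ccc2c(=O)ccoc2c1)Nc1cccc(NC(=O)c2cnc(C(F)(F)F)s2)c1` differs from compound 2 in one place: 2-(trifluoromethyl)-1,3-thiazol-5-yl in place of 4-nitrophenyl on a carbonyl carbon. Going by the values given here, the one measured step exchanged a substituent while keeping the 4-nitrophenyl ring; the change to compound 3 replaces that ring altogether, so the step from compound 1 to compound 2 bears on it only loosely, showing that changes at this end of the molecule move the number modestly. Among the compounds with values here, no measured pair shows a ring exchange of this kind. The expected step, a 1.7-fold higher number from compound 2 to compound 3 (0.22 log units; within the scatter), is small with no assured direction. Compound 3 is estimated at 25 nM, within 7 nM to 90 nM.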

Compound 3, half-maximal inhibitory concentration: 10 nM
Compound 3: the middle estimate sits 2.5-fold (0.40 log units) above what was measured, within the range that was stated.
By their numbers in this assay, from the lowest: compounds 3 and 2 (each within the scatter of the next); then compound 1.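

Exchanging the whole ring on the carbonyl carbon, and not just a substituent on it, leaves the number in this assay essentially where it was: the step (a 1.5-fold lower number from compound 2 to compound 3 (0.18 log units; within the scatter)) cannot separate the 2-(trifluoromethyl)-1,3-thiazol-5-yl group from the 4-nitrophenyl group. Set against the 4-fluorophenyl group, the same exchange gives a clear step (a 5.4-fold lower number from compound 1 to compound 3 (0.73 log units; beyond the scatter)), so at this position a five-membered aromatic ring with 2 hetero atoms reads as well as the best six-membered aromatic ring of carbon only seen so far, and compound 1 now stands apart from both of the others. No independent measurement accompanies these numbers, so the data offer no account of why compound 1 differs from the other two.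

The compounds shown leave open whether the result belongs to the ring or to its trifluoromethyl group, which a methyl group or a nitrile on the same 1,3-thiazole ring would begin to settle, and what an amine or a saturated ring such as piperidine would give on that carbonyl carbon. As far as these compounds go, how the three compounds read against any kinase other than the one in this assay also stays open.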